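A few compounds are considered here, and "the series" means these few. Any claim that something is new, unique, unknown or untested is made for them only; others in the source may bear on it.

Measured compounds:
- Compound 1 `Cc1ccc(C(=O)N(C(=S)OCCN2C(=O)c3ccccc3C2=O)c2ccc(C)cc2)cc1`: 83000 nM
- Compound 2 `Cc1ccc(N(C(=O)c2cc(F)ccc2F)C(=S)OCCN2C(=O)c3ccccc3C2=O)cc1`: 62000 nM
- Compound 3 `Cc1ccc(N(C(=O)c2cccc(Cl)c2Cl)C(=S)OCCN2C(=O)c3ccccc3C2=O)cc1`: 35000 nM

All three values come from an ADME assay on MT4 cells (Homo sapiens) for cytotoxicity, read by MTT assay; on this read-out higher numbers stand for lower toxicity in this test and lower numbers for higher toxicity in this test. The compounds share the core of compound 1 and differ only in the group on a carbonyl carbon. Compound 3, at 35000 nM, has the smallest number of the three, though not clearly so against its nearest neighbour: the gap there is a 1.8-fold lower number from compound 2 to compound 3 (0.25 log units; within the scatter). The gap to the furthest is a 2.4-fold lower number from compound 1 to compound 3 (0.38 log units; beyond the scatter).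

The next compound, compound 4 `COc1cccc(OC)c1C(=O)N(C(=S)OCCN1C(=O)c2ccccc2C1=O)c1ccc(C)cc1`, carries 2,6-dimethoxyphenyl in place of 2,3-dichlorophenyl on a carbonyl carbon.

Going by the values given here, all the measured steps change this same group. They are a 1.3-fold lower number from compound 1 to compound 2 (0.13 log units; within the scatter), a 1.8-fold lower number from compound 2 to compound 3 (0.25 log units; within the scatter) and a 2.4-fold lower number from compound 1 to compound 3 (0.38 log units; beyond the scatter), so only the last goes beyond the scatter, and only modestly. Among the compounds with values here, none of the measured compounds carries a methoxy group, so the data offer only a rough guide. With compound 3 at the low end of a narrow span, a small move back towards the other two seems the likeliest outcome. The expected step is a 1.6-fold higher number from compound 3 to compound 4 (0.20 log units; within the scatter), which would be small and may not clear the scatter. The estimate for compound 4 is 55000 nM, with an expected range from 25000 nM to 120000 nM.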

Compound 4, half-maximal cytotoxic concentration: 36000 nM
Compound 4: the middle estimate sits 1.5-fold (0.18 log units) above what was measured, within the range that was stated.
By their numbers in this assay, from the lowest: compounds 3, 4, 2 and 1 (each within the scatter of the next, the first and the last beyond it).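

In this assay the change from 2,3-dichlorophenyl to 2,6-dimethoxyphenyl on a carbonyl carbon gives a 1.0-fold higher number from compound 3 to compound 4 (0.01 log units; within the scatter), so this swap of chlorine for oxygen, with 0 hydrogen-bond acceptors leaving and 2 entering, produces no readable difference at this position. The two remaining comparisons extend that picture: there is a 1.7-fold lower number from compound 2 to compound 4 (0.24 log units; within the scatter), which cannot be told apart from repeat-measurement noise, and a 2.3-fold lower number from compound 1 to compound 4 (0.36 log units; beyond the scatter), which is beyond the scatter but only modest, so compound 1 with its 4-methylphenyl group stands apart from compound 3 and compound 4, while compound 2 goes against that split by staying within the scatter of compound 1. No measurement is at hand that would explain why these aromatic groups read so much alike.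

As far as these compounds go, all four compounds carry a six-membered aromatic ring of carbon only at this place, so it remains open whether an amine or a carboxylic acid on that ring would stay within this narrow span. The same question stands for a longer alkyl chain in place of the ring, and for changes elsewhere on the shared core.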